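The source may report more compounds than this note shows. Statements on the series, on what has been measured and on what is new or still open speak of the compounds shown alone.

Measured in a functional assay on the whole organism for inhibition, with Rattus norvegicus as the target, read by cytopathic effect and paw edema, at a dose of 100 mg/kg by the oral route; a higher number here means more inhibition at the dose given (going by the name of the read-out), a lower number less inhibition:

Compound 1 `CN(C)CCNC(=O)c1c(O)c2cccnc2n(-c2ccccc2)c1=O`: 18.4%
Compound 2 `O=C(Nc1ccc(Cl)cc1)c1c(O)c2cccnc2n(-c2ccccc2)c1=O`: 2.5%
Compound 3 `O=C(NCc1cccnc1)c1c(O)c2cccnc2n(-c2ccccc2)c1=O`: 14.7%

Compound 1 holds the highest of these three numbers, though its gap to compound 3 lies within the usual scatter; only the gap to compound 2 lies beyond it. Compound 4 `O=C(Nc1ccc(Cl)nc1)c1c(O)c2cccnc2n(-c2ccccc2)c1=O` differs from compound 1 in one place: 6-chloropyridin-3-yl in place of 2-(dimethylamino)ethyl on an amide-type nitrogen. The step that bears most on this is a number 15.9 percentage points lower from compound 1 to compound 2 (beyond the scatter), where 4-chlorophenyl likewise replaced 2-(dimethylamino)ethyl on the amide nitrogen. The reverse move, a number 12.2 percentage points higher from compound 2 to compound 3 (beyond the scatter), points the same way. A drop of similar size is therefore expected, a number 14.4 percentage points lower from compound 1 to compound 4 (beyond the scatter). Compound 4 is estimated at 4%, with a range from 0% to 14%.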

Compound 4, a percentage reported as inhibition, in the whole organism at one dose (the size of the read-out at that dose, not a potency): -4%
The estimate for compound 4 lay 8 percentage points above the measured number; the measured number lies below the stated range.
By their numbers in this assay, from the lowest: compounds 4 and 2 (each within the scatter of the next); then compounds 3 and 1 (each within the scatter of the next).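

In this assay, 6-chloropyridin-3-yl on the amide-type nitrogen gives a number 22.4 percentage points lower from compound 1 to compound 4 (beyond the scatter), and replacing the (pyridin-3-yl)methyl group with it gives a number 18.7 percentage points lower from compound 3 to compound 4 (beyond the scatter). Replacing 4-chlorophenyl with it gives a number 6.5 percentage points lower from compound 2 to compound 4 (within the scatter), so adding a nitrogen to the chlorinated aromatic ring does not separate these two compounds. Nothing measured here explains these changes. Going by these compounds, it remains open whether an unsubstituted phenyl on the amide nitrogen would also stay this low, and whether a longer chain ending in a dimethylamino group would differ from compound 1.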